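A few compounds are considered here, and "the series" means these few. Any claim that something is new, unique, unknown or untested is made for them only; others in the source may bear on it.

Working notes on the thioether series.

Compound 1 `Cc1cc(-n2cccc2)cn2c(CSCCc3ccccc3)cnc12` and compound 2 `Cc1cc(-n2cccc2)cn2c(CSCc3ccccc3)cnc12` share one core and differ in the group on the sulfur chain: phenyl in place of benzyl on a saturated chain carbon bound to a sulfur. In an ADME assay on HEL cells (Homo sapiens) for cytotoxicity, with a stated time of 3 days (on this read-out lower numbers stand for higher toxicity in this test and higher numbers for lower toxicity in this test), compound 1 gives 11 ug/mL, and in this assay compound 2 gives 17 ug/mL; the step is a 1.5-fold higher number from compound 1 to compound 2 (0.19 log units; within the scatter), so the two values cannot be told apart on this read-out.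

Compound 3 `Cc1cc(N2CCCC2)c2ncc(CSCCc3ccccc3)n2c1` carries the phenethyl chain of compound 1 on a different core; the difference between the two cores is not broken down here. In this assay compound 3 gives > 100 ug/mL, which is a limit of the assay and not a number, in line with the limit of > 100 ug/mL in this assay, at which 1 of the 3 values shown sits.

Compound 4 `Cc1cc(N2CCCC2)c2ncc(CSCc3ccccc3)n2c1` is not yet measured. It stands to compound 3 as compound 2 stands to compound 1: phenyl in place of benzyl on a saturated chain carbon bound to a sulfur. The same kind of change, at the same place, is thus available once as a measured step.

Expectation for compound 4 in this assay: the change is expected to be about as small as it was between compound 1 and compound 2, because a 1.5-fold higher number from compound 1 to compound 2 (0.19 log units; within the scatter) lies within the scatter, and the estimated step is a step that the limit leaves unreadable from compound 3 to compound 4. Since compound 3 reaches only a limit, compound 4 is expected most likely to reach the same limit, with an estimated value of 120 ug/mL, between 50 ug/mL and 300 ug/mL.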

Compound 4, half-maximal cytotoxic concentration: 52 ug/mL
Compound 4: the middle estimate sits 2.3-fold (0.36 log units) above what was measured, and the stated range covers the measured number.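

The new step reads an at least 1.9-fold lower number from compound 3 to compound 4 (0.28 log units; that floor lies within the scatter), which is a floor and not a full size: the true step may be larger, but not smaller. In this assay, as far as these compounds go, the change from benzyl to phenyl on a saturated chain carbon bound to a sulfur therefore does not carry over as one and the same step from one core to the other: the same change on two cores in this assay, a 1.5-fold higher number (0.19 log units; within the scatter) from compound 1 to compound 2 and an at least 1.9-fold lower number (0.28 log units; that floor lies within the scatter) from compound 3 to compound 4, at least 2.9-fold (0.47 log units) apart, beyond the scatter of two such steps Compound 3 gives > 100 ug/mL, which is a limit of the assay and not a number, so the size of the second step remains unknown, and a single pair on each core does not show why the two steps part or whether the gap holds for other chains on the sulfur.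

Open, from the compounds shown here alone, is whether the gap belongs to the core as a whole or to one part of it, as the difference between the two cores is not broken down in these compounds. Also open, going by these compounds, is how a longer chain on the sulfur, or a chain ending in an amine or a carboxylic acid in place of the phenyl, would read on each core.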